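Swapping Methoxycarbonyl for Iodo: An Expected Lipophilicity Shift

The source may report more compounds than this note shows. Statements on the series, on what has been measured and on what is new or still open speak of the compounds shown alone.

Compound 1, `COC(=O)c1cccc(/N=N/N(C)C)c1`, 2.77
Compound 2, `COC(=O)c1ccc(/N=N/N(C)C)cc1`, 2.77
Compound 3, `CN(C)/N=N/c1c(Br)cccc1Br`, 4.31

In a physicochemical assay for lipophilicity (a lower number here means a more polar compound, a higher number a more lipophilic compound), compound 2 gives 2.77, level with compound 1 at the digits shown, and the two together are the lowest of the three numbers, while compound 3 lies beyond the scatter above them. Compound 4, `CN(C)/N=N/c1ccc(I)cc1`, has not yet been measured. It differs from compound 2 in one place: iodo in place of methoxycarbonyl on an aromatic carbon. For the measured compounds named here, no measured pair shows this exact step, so the expectation rests on the wider picture. Because compound 3, which carries bromo groups on its ring, gives 4.31, a rise beyond the scatter is expected here, a step estimated at a number 1.13 log units higher from compound 2 to compound 4 (beyond the scatter). For compound 4 the estimate is 3.9, with an expected range from 3.5 to 4.3.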

Compound 4, partition coefficient: 3.71
Compound 4: middle estimate off by 0.19 log units, on the high side; measured number inside the range.
By their numbers in this assay, from the lowest: compounds 1 and 2 (each within the scatter of the next); then compound 4; then compound 3.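

For the compounds shown here, replacing methoxycarbonyl with iodo on this aromatic carbon, para to a group of 5 heavy atoms, gives the first direct step at this position: in this assay, it is a number 0.94 log units higher from compound 2 to compound 4 (beyond the scatter). The change takes away 2 hydrogen-bond acceptors and replaces 4 heavy atoms with 1, but nothing available shows which of these differences matters, if either does. From the compounds shown here alone, it remains open whether iodo would give a similar step on the ring carbon that carries methoxycarbonyl in compound 1. Also open, going by these compounds, is how an amine or a carboxylic acid at the position changed here would compare.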